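The source may report more compounds than this note shows. Statements on the series, on what has been measured and on what is new or still open speak of the compounds shown alone.

Measured so far in a functional assay for agonist activity at 5-hydroxytryptamine receptor 4 (Cavia porcellus); on this read-out higher numbers stand for larger maximal responses and lower numbers for smaller maximal responses:
compound 1, `CN1CCN(CCCNC(=O)n2c(=O)n(C3CC3)c3ccccc32)CC1`: 0.46
compound 2, `CC(C)n1c(=O)n(C(=O)NCCN2CCN(C)CC2)c2cc(F)ccc21`: 0.67
compound 3, `CCn1c(=O)n(C(=O)NCCN2CCN(C)CC2)c2ccccc21`: < 0.3

Compound 3 gives no number in this assay, only a limit, < 0.3. Within the data shown here, it is the single member of the trio that sits at that limit, (the limit of < 0.3 in this assay, at which 1 of the 3 values shown sits), so its position against compound 1 and compound 2 can be read only as a bound, not as a distance.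

Compound 4, `CN1CCN(CCNC(=O)n2c(=O)[nH]c3ccccc32)CC1`, differs from compound 3 in one place: hydrogen in place of ethyl on an aromatic nitrogen. Among the measured compounds shown here, no measured pair in the set isolates this change, so the step is unanchored. The expectation is a step of modest size upward or none beyond the scatter, a number at least 0.020 higher from compound 3 to compound 4 (that floor lies within the scatter). Compound 4 is therefore estimated at 0.32, within 0.15 to 0.55, with a real chance that the assay again reports only a limit.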

Compound 4, intrinsic activity: the largest response reached, as a fraction of the reference agonist's: 0.35
Beside the measured number, compound 4's estimate is 0.030 below it; the range from low to high includes it.
By their numbers in this assay, from the lowest: compound 4; then compound 1; then compound 2. At a limit, below all of these: compound 3.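

Hydrogen in place of ethyl on an aromatic nitrogen gives in this assay a number at least 0.050 higher from compound 3 to compound 4 (that floor lies within the scatter) and is therefore not shown to move the response beyond the scatter. Compound 3 is a limit and not a number, so this step is only a floor: the limit of < 0.3 in this assay, at which 1 of the 4 values shown sits. With hydrogen at this position, compound 4 still returns a number in this assay.

Open, as far as these compounds go, is how methyl or a longer chain such as n-butyl on this nitrogen would read with the rest of compound 4 unchanged. Also open, from the compounds shown here alone, is the size of the ethyl-to-hydrogen step beyond its floor.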